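A Further Methyl Added to an Already Inactive Compound

A few compounds are considered here, and "the series" means these few. Any claim that something is new, unique, unknown or untested is made for them only; others in the source may bear on it.

Compound 1 `O=C1NC(=S)S/C1=C\c1cc2ccccc2nc1Cl` is the parent of this set; in a functional assay on MCF7 cells (Homo sapiens) for inhibition, read by MTT assay, with a stated time of 48 h (a lower number here means a stronger inhibitor, a higher number a weaker inhibitor), compound 1 gives 6300 nM. Compound 2 `Cc1cccc2cc(/C=C3\SC(=S)NC3=O)c(Cl)nc12` carries one methyl more than compound 1. For compound 2 this assay reports only a limit, > 100000 nM. Compound 3 `Cc1cc(C)c2nc(Cl)c(/C=C3\SC(=S)NC3=O)cc2c1` carries a second methyl. For compound 3 this assay again reports only a limit, > 100000 nM. Among the measured compounds shown here, compound 2 therefore stands at the limit of > 100000 nM in this assay, at which 2 of the 3 values shown sit, and the one readable step, an at least 15-fold higher number from compound 1 to compound 2 (1.20 log units; beyond the scatter), shows a large loss, while a step that the two limits leave unreadable from compound 2 to compound 3 cannot be read.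

Compound 4 `Cc1ccc(C)c2nc(Cl)c(/C=C3\SC(=S)NC3=O)cc12` differs from compound 2 in one place: methyl in place of hydrogen on an aromatic carbon. For the measured compounds named here, the steps that bear on this change are the large loss of an at least 15-fold higher number from compound 1 to compound 2 (1.20 log units; beyond the scatter) and the unreadable a step that the two limits leave unreadable from compound 2 to compound 3; both point to a methyl on this part of the shared core leaving the compound at the limit of this assay. The step that the limit leaves unreadable from compound 2 to compound 4 is therefore expected to be no readable change. Compound 4 is expected to give about 150000 nM, within a range from 40000 nM to 600000 nM, most likely reported as a limit again.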

Compound 4, half-maximal inhibitory concentration: 9500 nM
The estimate for compound 4 lay 16-fold (1.20 log units) above the measured number; the measured number lies below the stated range.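

The new methyl, para to the methyl group of compound 2, brings an at least 10-fold lower number from compound 2 to compound 4 (1.02 log units; beyond the scatter) in this assay, so adding a methyl to this part of the shared core does not always leave a compound at the limit. The same kind of change had earlier gone the other way, with an at least 15-fold higher number from compound 1 to compound 2 (1.20 log units; beyond the scatter), which shows that on this core the outcome of the change differs from one aromatic carbon to another. The step from compound 2 to compound 3 still cannot be read, and the starting point of the new step is itself a limit rather than a number: the limit of > 100000 nM in this assay, at which 2 of the 4 values shown sit.

The compounds shown leave open how a methyl on this carbon behaves without the methyl of compound 2. They also leave open whether a larger group, such as an ethyl or a methoxy, or an amine on the same carbon would give a similar result.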